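Expected Loss on Saturating the Amide Acyl Group

A few compounds are considered here, and "the series" means these few. Any claim that something is new, unique, unknown or untested is made for them only; others in the source may bear on it.

Measured so far:
compound 1 `C=C(C)C(=O)N(Cc1ccc(OC)c(O)c1)c1cc(OC)c(OC)c(OC)c1` — 200 nM
compound 2 `COc1ccc(CN(C(=O)CCCCCl)c2cc(OC)c(OC)c(OC)c2)cc1O` — 770 nM
compound 3 `C/C=C/C(=O)N(Cc1ccc(OC)c(O)c1)c1cc(OC)c(OC)c(OC)c1` — 67 nM

In a functional assay on KYSE-450 cells (Homo sapiens) for inhibition, read by MTT assay, with a stated time of 48 h (a lower number here means a stronger inhibitor, a higher number a weaker inhibitor), compound 3 gives the lowest of the three numbers. Its nearest neighbour is compound 1, the step of a 3.0-fold lower number from compound 1 to compound 3 (0.47 log units; beyond the scatter) being modest, while the step of an 11-fold lower number from compound 2 to compound 3 (1.06 log units; beyond the scatter) is large; both steps lie beyond the scatter, so compound 3 stands as the most potent of the measured set.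

Compound 4 `COc1ccc(CN(C(=O)CO)c2cc(OC)c(OC)c(OC)c2)cc1O` is not yet measured. It differs from compound 3 at the carbonyl carbon: hydroxymethyl in place of prop-1-en-1-yl on a carbonyl carbon. The group that leaves carries the one double bond outside aromatic rings, and the group that enters has none, bringing instead a hydrogen-bond donor and acceptor.

Going by the values given here, two measured steps bear on this. The step of a 3.0-fold lower number from compound 1 to compound 3 (0.47 log units; beyond the scatter) shows that changing the unsaturated acyl group within the set shifts the number modestly. Among the compounds with values here, the step of an 11-fold lower number from compound 2 to compound 3 (1.06 log units; beyond the scatter) shows that the saturated 4-chlorobutyl analogue sits far higher than compound 3; the change to compound 4 likewise removes the double bond, though hydroxymethyl is not 4-chlorobutyl and no measured compound carries it.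

Compound 4 is therefore expected to give a higher number than compound 3, roughly a 10-fold higher number from compound 3 to compound 4 (1.02 log units; beyond the scatter), with an estimate of 700 nM and a range from 200 nM to 3000 nM.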

Compound 4, half-maximal inhibitory concentration: 370 nM
For compound 4 the middle estimate is 1.9-fold (0.28 log units) above the measured one; measured number inside the range.
By their numbers in this assay, from the lowest: compound 3; then compounds 1 and 4 (each within the scatter of the next); then compound 2.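

In this assay the hydroxymethyl group shows that an acyl group with no double bond need not carry the large penalty seen with 4-chlorobutyl: the loss against prop-1-en-1-yl is only modest (a 5.5-fold higher number from compound 3 to compound 4 (0.74 log units; beyond the scatter)). The two saturated groups also separate from each other (a 2.1-fold lower number from compound 2 to compound 4 (0.32 log units; beyond the scatter)), so removing the double bond does not lead to one fixed level, and what enters matters as well. Compound 1 keeps a double bond in its 1-methylethenyl group, yet it cannot be told apart from compound 4 (a 1.9-fold higher number from compound 1 to compound 4 (0.27 log units; within the scatter)), so a double bond alone does not set the order, and among these compounds only the prop-1-en-1-yl group of compound 3 stands apart from all the others. Nothing among the data given explains this ranking.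

Going by these compounds, whether a plain propyl group, the saturated counterpart of prop-1-en-1-yl, would hold the number of compound 3 remains open. So does the part played by the hydroxy group of compound 4, which a methoxymethyl or aminomethyl group on the carbonyl carbon could test.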